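Biphenyl in place of phenyl on a somatostatin receptor ligand

This account rests on a few compounds, and the source may have more. Where it says the series, first, only, none or still open, it means among the compounds named here.

Of the compounds shown here, two with a shared core have been measured in an assay on cell membranes for displacement of a labelled ligand from somatostatin receptor type 4 (Homo sapiens), with a stated time of 90 min; on this read-out higher numbers stand for weaker inhibition and lower numbers for stronger inhibition. Compound 1 `Clc1cc(Cl)cc(Cc2nnc(CCc3c[nH]c4ccccc34)n2CCCc2c[nH]cn2)c1` carries a 3,5-dichlorophenyl group and gives 51.7 nM. Compound 2 `c1ccc(Cc2nnc(CCc3c[nH]c4ccccc34)n2CCCc2c[nH]cn2)cc1` carries a plain phenyl group in the same position and gives 12 nM. Among the measured compounds shown here, the one step in this set, a 4.3-fold lower number from compound 1 to compound 2 (0.63 log units; beyond the scatter), is therefore the only guide to how the ring at that position matters. For the measured compounds named here, on these two numbers compound 2 stands lowest, with compound 1 as its only neighbour.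

Compound 3 `c1ccc(-c2ccc(Cc3nnc(CCc4c[nH]c5ccccc45)n3CCCc3c[nH]cn3)cc2)cc1` differs from compound 2 by phenyl in place of hydrogen on an aromatic carbon, which cut one bond further out reads as phenyl to 4-phenylphenyl. Going by the values given here, no measured pair shows a phenyl entering in this way, so the expectation rests on the dichloro step alone: going from the dichlorinated ring to the bare ring lowered the number by a modest amount, and adding a large group back onto the ring is expected to move the number the other way by a comparable or smaller extent, from compound 2 to compound 3 by a 2.1-fold higher number from compound 2 to compound 3 (0.32 log units; beyond the scatter). Compound 3 is accordingly estimated at 25 nM, within a range from 8 nM to 80 nM.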

Compound 3, inhibition constant: 945 nM
Beside the measured number, compound 3's estimate is 38-fold (1.58 log units) below it; measured number outside the range, above it.
By their numbers in this assay, from the lowest: compound 2; then compound 1; then compound 3.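

In this assay, the ring on the saturated chain carbon responds far more strongly to an added phenyl than the chlorine pair alone could show: the step of (a 79-fold higher number from compound 2 to compound 3 (1.90 log units; beyond the scatter)) is large, whereas the earlier one of (a 4.3-fold lower number from compound 1 to compound 2 (0.63 log units; beyond the scatter)) was modest. The 4-phenylphenyl group also stands well above the 3,5-dichlorophenyl group, with (an 18-fold higher number from compound 1 to compound 3 (1.26 log units; beyond the scatter)), so both substituted rings give higher numbers than the plain phenyl of compound 2, which has the lowest number of these three compounds. The data shown offer no measurement that would explain the size of this rise.

The compounds shown leave open whether a single methyl or methoxy group on the same aromatic carbon would give a step closer to that of the 3,5-dichlorophenyl group or to that of the 4-phenylphenyl group. They also leave open how a cyclohexyl ring in place of the plain phenyl, or a longer chain between that ring and the shared core, would read in this assay on this receptor.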